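Notes on the aryl group: from compound 2 to compound 3

The compounds below may be only part of what the source reports. "The series", "measured", "known", "first", "only" and "open" are said of these compounds alone.

Measured in a functional assay on MCF7 cells (Homo sapiens) for antiproliferative activity, read by MTT assay, with a stated time of 72 h; a higher number here means a weaker inhibitor, a lower number a stronger inhibitor:
- compound 1 `COc1ccccc1-c1ccc2ncn(-c3cc(OC)c(OC)c(OC)c3)c2c1`: 1750 nM
- compound 2 `COc1ccc(-c2ccc3ncn(-c4cc(OC)c(OC)c(OC)c4)c3c2)cc1F`: 520 nM

In this assay compound 2 has the lower of the two numbers, at 520 nM. Compound 3 `COc1cc(-n2cnc3ccc(-c4ccccc4)cc32)cc(OC)c1OC` is still unmeasured. Its change is phenyl in place of 3-fluoro-4-methoxyphenyl on an aromatic carbon. For the measured compounds named here, one measured step bears on this, a 3.4-fold lower number from compound 1 to compound 2 (0.53 log units; beyond the scatter), which is modest and also exchanges the aryl group on an aromatic carbon. Going by the values given here, no measured compound carries plain phenyl, so the evidence is indirect. A modest rise in the number is expected, and the expected step is a 2.1-fold higher number from compound 2 to compound 3 (0.33 log units; beyond the scatter). For compound 3 the estimated value is 1100 nM, with an expected range of 400 nM to 3000 nM.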

Compound 3, half-maximal inhibitory concentration: 2290 nM
For compound 3 the middle estimate is 2.1-fold (0.32 log units) below the measured one; measured number inside the range.
By their numbers in this assay, from the lowest: compound 2; then compounds 1 and 3 (each within the scatter of the next).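

Stripping the 3-fluoro-4-methoxyphenyl group down to plain phenyl gives a 4.4-fold higher number from compound 2 to compound 3 (0.64 log units; beyond the scatter), so substitution on this aryl ring can shift the number beyond the scatter. Plain phenyl and the 2-methoxyphenyl group read alike, with a 1.3-fold higher number from compound 1 to compound 3 (0.12 log units; within the scatter), so among these three compounds only compound 2 stands apart. Nothing available explains this difference.

As far as these compounds go, whether the fluorine or the methoxy carries the effect stays open, as both leave in the same step. From the compounds shown here alone, how an amine or a carboxylic acid on this ring would read is also open.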